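The source may hold more compounds than are shown below. What is called first, only, known or untested is meant among the compounds shown, and "the series" means these compounds.

In a functional assay on K562 cells (Homo sapiens) for cytotoxicity, read by WST assay, with a stated time of 72 h (a higher number here means a weaker inhibitor, a lower number a stronger inhibitor), compound 2 `COc1cc2c(Nc3nc4ccc(C(=O)Nc5c(C)cc(C)cc5C)cc4s3)ncnc2cc1OCCCN1CCCCC1` gives 9300 nM. For the measured compounds named here, its only measured neighbour, compound 1 `COc1cc2c(Nc3nc4ccc(C(=O)Nc5c(C)cccc5C)cc4s3)ncnc2cc1OCCCN1CCCCC1`, gives 13700 nM, and the step of a 1.5-fold lower number from compound 1 to compound 2 (0.17 log units; within the scatter) lies within the scatter, so the two numbers stand on a par. Compound 3 `COc1cc2c(Nc3nc4ccc(C(=O)Nc5c(C)cc(C)cc5C)cc4s3)ncnc2cc1OCCCN1CCCCC1C` differs from compound 2 by methyl in place of hydrogen on a saturated ring carbon. Going by the values given here, the single measured step, a 1.5-fold lower number from compound 1 to compound 2 (0.17 log units; within the scatter), concerns a methyl on an aromatic carbon and says little about a methyl on the piperidin-1-yl ring, so no step beyond the scatter is expected in this assay. Compound 3 is therefore estimated at 9300 nM, within 4000 nM to 25000 nM, an expected step of no change at the digits printed from compound 2 to compound 3 (within the scatter).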

Compound 3, half-maximal inhibitory concentration: 3500 nM
The estimate for compound 3 lay 2.7-fold (0.42 log units) above the measured number; measured number outside the range, below it.
By their numbers in this assay, from the lowest: compound 3; then compounds 2 and 1 (each within the scatter of the next).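

In this assay, the change to 2-methylpiperidin-1-yl gives a 2.7-fold lower number from compound 2 to compound 3 (0.42 log units; beyond the scatter), so a single methyl on a saturated ring carbon next to the ring nitrogen produces a modest step beyond the scatter. The earlier methyl on an aromatic carbon, a 1.5-fold lower number from compound 1 to compound 2 (0.17 log units; within the scatter), stayed within the scatter and gave no sign that this ring would respond. Nothing available explains the step.

The compounds shown leave open whether an ethyl on the same ring carbon would lower the number further. They also leave open how a morpholine in place of the piperidine ring would read.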